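Hydrazone arylation on a quinolinone oxime series

The compounds below may be only part of what the source reports. "The series", "measured", "known", "first", "only" and "open" are said of these compounds alone.

Compound 1 `O=c1[nH]c2ccccc2cc1/C=N/O` gives 118000 nM in a functional assay, read by spectrophotometry, with a stated time of 30 min; a higher number here means a weaker inhibitor, a lower number a stronger inhibitor.
Compound 2 `N/N=C/c1cc2ccccc2[nH]c1=O` gives 729000 nM in this assay.
Compound 3 `CCCC/N=C/c1cc2ccccc2[nH]c1=O` gives 439000 nM in this assay.

Compound 2 stands at the highest number of the three in this assay. Its nearest neighbour is compound 3, and the gap from compound 2 to compound 3 is within the scatter (a 1.7-fold lower number from compound 2 to compound 3 (0.22 log units; within the scatter)); the furthest is compound 1, and the move from compound 1 to compound 2 is beyond it (a 6.2-fold higher number from compound 1 to compound 2 (0.79 log units; beyond the scatter)). The third step, from compound 1 to compound 3, is also beyond the scatter (a 3.7-fold higher number from compound 1 to compound 3 (0.57 log units; beyond the scatter)).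

Compound 4 `O=c1[nH]c2ccccc2cc1/C=N/Nc1ccccc1` differs from compound 2 in one place: phenyl in place of hydrogen on an amine nitrogen. Within the data shown here, no measured step touches that amine nitrogen directly. The step that bears most closely on it is the exchange at the double-bonded nitrogen, from compound 2 to compound 3, where replacing amino with butyl stayed within the scatter. The two other steps show that only the hydroxy group of compound 1 has so far given a clearly lower number.

On that basis the step from compound 2 to compound 4 is expected to be small, a 1.6-fold lower number from compound 2 to compound 4 (0.21 log units; within the scatter), in this assay. Compound 4 is therefore estimated at 450000 nM, within a range from 120000 nM to 1500000 nM.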

Compound 4, half-maximal inhibitory concentration: 76500 nM
For compound 4 the middle estimate is 5.9-fold (0.77 log units) above the measured one, and the stated range ends above it.
By their numbers in this assay, from the lowest: compounds 4 and 1 (each within the scatter of the next); then compounds 3 and 2 (each within the scatter of the next).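

Among these compounds, on the amine nitrogen of compound 2, phenyl in place of hydrogen gives a 9.5-fold lower number from compound 2 to compound 4 (0.98 log units; beyond the scatter) in this assay, so a substituent at this nitrogen can shift the number beyond the scatter, something the earlier steps had not tested. Compound 4 at 76500 nM and compound 1 at 118000 nM lie within the scatter of each other, which means the hydroxy group of compound 1 no longer stands alone among these compounds in giving a clearly lower number than compound 2 and its amino group. Nothing measured here accounts for the size of this step, and no separate data on the compounds bear on it.

The compounds shown leave open whether the step depends on the aromatic ring of the phenyl group or would follow from other groups on the same amine nitrogen, such as a methyl, a cyclohexyl or a benzyl group. They also leave open how the number would respond to a chlorine atom or a methoxy group carried on the phenyl ring of compound 4, or whether a second group on that amine nitrogen would be tolerated.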